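This account rests on a few compounds, and the source may have more. Where it says the series, first, only, none or still open, it means among the compounds named here.

Three analogues share one core. Compound 1 `COc1cc2c(Oc3ccc(NC(=O)N/N=C/c4ccncc4)cc3F)ccnc2cc1OCCCN1CCCCC1` has a result of "not determined" (no result reported) in an ADME assay on PBL cells (Homo sapiens) for cytotoxicity, read by MTT assay, with a stated time of 72 h; a higher number here means a weaker inhibitor, a lower number a stronger inhibitor. Compound 2 `COc1cc2c(Oc3ccc(NC(=S)N/N=C/c4ccccc4)cc3F)ccnc2cc1OCCCN1CCCCC1` gives 78400 nM in this assay, and compound 3 `COc1cc2c(Oc3ccc(/C=N/NC(=O)Nc4ccccc4)cc3F)ccnc2cc1OCCCN1CCCCC1` gives 25500 nM in this assay. Within the data shown here, compound 3 thus holds the lower of the two available numbers, the only known comparison being the step of a 3.1-fold lower number from compound 2 to compound 3 (0.49 log units; beyond the scatter). Compound 4 `COc1cc2c(Oc3ccc(/C=N/NC(=O)Nc4ccc(F)cc4Br)cc3F)ccnc2cc1OCCCN1CCCCC1` differs from compound 3 by 2-bromo-4-fluorophenyl in place of phenyl on an amide-type nitrogen. Among the measured compounds shown here, no measured step touches this part of the molecule: the one known step concerns a different region, so the data point in neither direction. Compound 4 is therefore expected to sit close to compound 3 in this assay. The expected step is a 1.0-fold lower number from compound 3 to compound 4 (0.01 log units; within the scatter), within the scatter. The estimate for compound 4 is 25000 nM, between 8000 nM and 80000 nM.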

Compound 4, half-maximal inhibitory concentration: 36400 nM
The estimate for compound 4 lay 1.5-fold (0.16 log units) below the measured number; low and high end bracket the measured number.
By their numbers in this assay, from the lowest: compounds 3 and 4 (each within the scatter of the next); then compound 2.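

In this assay, the exchange of phenyl for 2-bromo-4-fluorophenyl on the amide-type nitrogen gives a 1.4-fold higher number from compound 3 to compound 4 (0.15 log units; within the scatter) and so leaves compound 3 and compound 4 within the scatter of each other. Among these compounds, this is the first look at this part of the molecule, and it shows that this substitution on the ring does not separate the two compounds in this read-out. Nothing available explains this result. Going by these compounds, it remains open whether bromine or fluorine alone would behave in the same way. Also open, on these data alone, is whether a morpholine or a carboxylic acid in place of the phenyl would give a step beyond the scatter.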